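The compounds below may be only part of what the source reports. "The series", "measured", "known", "first", "only" and "open" are said of these compounds alone.

Compound 1 `CC(=O)c1ccc(OCCCN2CC[C@H](NC(=O)c3ccc(C#N)cc3)C2)cc1` sits at the top of the three numbers recorded in an assay on isolated protein for binding affinity to histamine H2 receptor (Homo sapiens) (on this read-out higher numbers stand for weaker inhibition and lower numbers for stronger inhibition), where compound 1 gives 6100 nM. Compound 2 `N#Cc1ccc(S(=O)(=O)N[C@H]2CCN(CCCOc3ccc(C(=O)C4CC4)cc3)C2)cc1` gives 1600 nM in this assay, and compound 3 `O=C(c1ccc(OCCCN2CC[C@H](NS(=O)(=O)c3cccc(Cl)c3)C2)cc1)C1CC1` gives 700 nM; the gap from compound 1 to compound 2 and the larger gap from compound 1 to compound 3 both lie beyond the scatter. Among these three, only one single-point step is available: a 2.3-fold lower number from compound 2 to compound 3 (0.36 log units; beyond the scatter).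

Compound 4 `CC(=O)c1ccc(OCCCN2CC[C@H](NC(=O)c3cccnc3)C2)cc1` differs from compound 1 by pyridin-3-yl in place of 4-cyanophenyl on a carbonyl carbon. Within the data shown here, the one measured step concerns a different exchange at a different place, a sulfonyl sulfur rather than a carbonyl carbon, and it was only modest in size; it therefore speaks to the present change only indirectly. Among the measured compounds shown here, nothing among the measured compounds shows a pyridin-3-yl group, so the direction of the change is not anchored by data. On this basis, the step from compound 1 to compound 4 in this assay is expected to be small, and possibly within the scatter, as a 1.2-fold lower number from compound 1 to compound 4 (0.09 log units; within the scatter). Compound 4 is accordingly estimated at 5000 nM in this assay, with an expected range from 1500 nM to 16000 nM.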

Compound 4, inhibition constant: 3500 nM
Compound 4: middle estimate off by 1.4-fold (0.15 log units), on the high side; the range from low to high includes it.
By their numbers in this assay, from the lowest: compound 3; then compound 2; then compounds 4 and 1 (each within the scatter of the next).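

In this assay, the first exchange seen on this carbonyl carbon gives a 1.7-fold lower number from compound 1 to compound 4 (0.24 log units; within the scatter) and so leaves compound 1 and compound 4 within the scatter of each other. This position therefore accepts pyridin-3-yl in place of 4-cyanophenyl without a readable change in the number, even though the exchange removes the triple bond, replaces a ring of carbon only with a ring holding a hetero atom, and takes the group from 8 heavy atoms to 6, while the count of hydrogen-bond acceptors stays the same. Nothing measured explains why this exchange leaves the number within the scatter, and no outside data bear on the result. Still open, on these data alone, is whether 3-chlorophenyl, which on a sulfonyl sulfur gave a 2.3-fold lower number from compound 2 to compound 3 (0.36 log units; beyond the scatter), would produce a step beyond the scatter on this carbonyl carbon. As far as these compounds go, it is also open whether pyridin-4-yl, a saturated cyclohexyl group or a phenyl ring carrying a carboxylic acid would keep the number within the scatter of compound 1 in this assay, or move it clearly in either direction.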